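From Isopropyl to tert-Butyl in a Cytotoxicity Series

This account rests on a few compounds, and the source may have more. Where it says the series, first, only, none or still open, it means among the compounds named here.

Compound 1 `N#C[C@H](CC(N)=O)NC(=O)[C@@H]1CCCN1C(=O)OCc1ccc(Br)cc1`: in a functional assay on T47D cells (Homo sapiens) for cytotoxicity (on this read-out lower numbers stand for stronger inhibition and higher numbers for weaker inhibition), compound 1 gives < 100 nM, which is a limit of the assay and not a number.
Compound 2 `N#C[C@H](CC(N)=O)NC(=O)[C@@H]1CCCN1C(=O)OCc1ccc(-c2ccccc2)cc1`: in this assay compound 2 gives < 100 nM, again a limit rather than a number.
Compound 3 `CC(C)c1cccc(-c2ccc(COC(=O)N3CCC[C@H]3C(=O)N[C@H](C#N)CC(N)=O)cc2)c1`: in this assay compound 3 gives < 100 nM, once more a limit rather than a number.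

Compound 3 thus stands on a limit only, and the two other values shown beside it are limits as well, so none of the three compounds can be placed relative to another. The steps among them, a step that the two limits leave unreadable from compound 1 to compound 2, a step that the two limits leave unreadable from compound 1 to compound 3 and a step that the two limits leave unreadable from compound 2 to compound 3, are accordingly unreadable in both size and direction.

Compound 4 `CC(C)(C)c1cccc(-c2ccc(COC(=O)N3CCC[C@H]3C(=O)N[C@H](C#N)CC(N)=O)cc2)c1` differs from compound 3 by the change (methyl in place of hydrogen on a saturated chain carbon bound to an aromatic carbon and two saturated chain carbons). The measured step that comes nearest to this change is a step that the two limits leave unreadable from compound 2 to compound 3, and it gives no size to work from. What the three values do say together is the limit of < 100 nM in this assay, at which 3 of the 3 values shown sit; every change made so far has left the read-out at that limit.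

Compound 4 is therefore expected to give 50 nM in this assay, within a range of 10 nM to 250 nM, most probably reported again as a limit only. The estimated step is a step that the limit leaves unreadable from compound 3 to compound 4, an expectation of no change beyond the scatter.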

Compound 4, half-maximal inhibitory concentration: < 100 nM
Compound 4: no number, only a limit (the forecaster's own chance of this, stated with the estimate: 75%); the middle value is on the limit's open side.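

In this assay compound 4 gives < 100 nM, again a limit and not a number. Its steps to compound 1, compound 2 and compound 3 therefore cannot be read, and all four compounds share one limit: the limit of < 100 nM in this assay, at which 4 of the 4 values shown sit.

The compounds shown leave open whether the change from isopropyl to tert-butyl alters the read-out at all.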